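Swapping furan for pyridine on a diaryl core

This account rests on a few compounds, and the source may have more. Where it says the series, first, only, none or still open, it means among the compounds named here.

Measured compounds:
- compound 1, `Oc1ccccc1-c1cc(-c2ccco2)cc(-c2ccccc2O)n1`: > 50000 nM
- compound 2, `Oc1ccc(-c2cc(-c3ccco3)cc(-c3ccccc3O)n2)cc1`: > 50000 nM
- compound 3, `Oc1ccc(-c2cc(-c3ccco3)cc(-c3ccc(O)cc3)n2)cc1`: 14000 nM

In a functional assay on HCT-15 cells (Homo sapiens) for cytotoxicity, read by CCK-8 assay (on this read-out higher numbers stand for weaker inhibition and lower numbers for stronger inhibition), compound 2 reaches only the limit of the assay, > 50000 nM, so no number is known for it. Compound 1 sits at the same limit, (the limit of > 50000 nM in this assay, at which 2 of the 3 values shown sit). Compound 3 is the only one of the three with a number, and the step of an at least 3.5-fold lower number from compound 2 to compound 3 (0.55 log units; beyond the scatter) shows how far compound 3 lies from that limit, while the step that the two limits leave unreadable from compound 1 to compound 2 cannot be read at all.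

Compound 4, `Oc1ccc(-c2cc(-c3cccnc3)cc(-c3ccccc3O)n2)cc1`, differs from compound 2 in one place: pyridin-3-yl in place of furan-2-yl on an aromatic carbon. For the measured compounds named here, none of the measured steps changes the furan-2-yl group; both concern a hydroxyphenyl group, so no measured step bears directly on this change. With compound 2 at the limit, the expected step of a number no higher from compound 2 to compound 4 (the limit leaves the size open) is therefore unreadable in size and direction. Compound 4 is estimated at 50000 nM, within 15000 nM to 150000 nM, with a good chance that only a limit is reported again.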

Compound 4, half-maximal inhibitory concentration: > 50000 nM
Compound 4: a limit, no number; the forecaster's own chance of this, stated with the estimate: 60%; the middle value sits exactly at the limit.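

Compound 4 gives > 50000 nM as a limit, not a number. The change from furan-2-yl to pyridin-3-yl between compound 2 and compound 4 therefore cannot be read, because both compounds stop at a limit: the limit of > 50000 nM in this assay, at which 3 of the 4 values shown sit.

The compounds shown leave open whether this change affects cytotoxicity at all.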